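From a Carboxylic Acid to a Methyl Amide

The source may report more compounds than this note shows. Statements on the series, on what has been measured and on what is new or still open speak of the compounds shown alone.

Measured compounds:
compound 1, `CC(=O)NCC[C@@H]1C[C@@H](c2ccc(F)c(F)c2)[C@H](NC(=O)c2cc(-c3c(Cl)cnn3C)c(Cl)o2)CN1`: 920 nM
compound 2, `Cn1ncc(Cl)c1-c1cc(C(=O)N[C@@H]2CN[C@H](CC(=O)O)C[C@H]2c2ccc(Cl)c(Cl)c2)oc1Cl`: 4020 nM

In a functional assay on HCT-116 cells (Homo sapiens) for antiproliferative activity, read by sulforhodamine B assay, with a stated time of 72 h (on this read-out lower numbers stand for stronger inhibition and higher numbers for weaker inhibition), compound 1 gives 920 nM, while compound 2 gives 4020 nM, the higher of the two numbers and weaker by a margin beyond the scatter. The unmeasured compound 3, `CNC(=O)C[C@@H]1C[C@@H](c2ccc(Cl)c(Cl)c2)[C@H](NC(=O)c2cc(-c3c(Cl)cnn3C)c(Cl)o2)CN1`, differs from compound 2 by methylamino in place of hydroxy on a carbonyl carbon. Going by the values given here, no single-change step between measured compounds exists, so the size of this change cannot be read from a comparison. A moderate step toward a lower number is expected, beyond the scatter. Compound 3 is therefore estimated at 1500 nM (range 600 nM to 4000 nM), meaning an expected step of a 2.7-fold lower number from compound 2 to compound 3 (0.43 log units; beyond the scatter).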

Compound 3, half-maximal inhibitory concentration: 450 nM
Beside the measured number, compound 3's estimate is 3.3-fold (0.52 log units) above it, outside the stated range (below it).
By their numbers in this assay, from the lowest: compound 3; then compound 1; then compound 2.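

In this assay, methylamino in place of hydroxy on a carbonyl carbon gives an 8.9-fold lower number from compound 2 to compound 3 (0.95 log units; beyond the scatter). Going by these compounds alone, this is the first direct reading at this position, and it shows that the carboxy group is not needed for activity in these cells, since the methylcarbamoyl group gives the stronger number of the pair. No available measurement gives a reason for this step. The compounds shown leave open whether an unsubstituted amide, an ethyl amide or an amine at this place would lower the number further.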